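The compounds below may be only part of what the source reports. "The series", "measured", "known", "first", "only" and "open" are said of these compounds alone.

Measured compounds in an ADME assay on liver for metabolic stability, with Liver microsome (Homo sapiens) as the target, read by LC-MS, using microsomes; a lower number here means slower removal, a higher number faster removal of the compound:
Compound 1 `CC(C)(C)C[C@@H](O)C(=O)N1[C@@H]2C[C@@H]2C[C@H]1C(=O)NCc1cc(Cl)ccc1-n1cnnn1` gives 71 mL.min-1.g-1.
Compound 2 `Cc1cccc([C@@H](O)C(=O)N2N=CC[C@H]2C(=O)NCc2cc(Cl)ccc2-n2cnnn2)c1` gives < 12 mL.min-1.g-1, which is a limit of the assay and not a number.

Compound 2 therefore stands at the limit of < 12 mL.min-1.g-1 in this assay, at which 1 of the 2 values shown sits, so only a bound is known for it, whereas compound 1 has a proper number and sits clearly away from that bound. The two compounds also differ in their cores, so their values cannot be read as a single step.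

Compound 3 `CC(C)CC[C@@H](O)C(=O)N1N=CC[C@H]1C(=O)NCc1cc(Cl)ccc1-n1cnnn1` differs from compound 2 in one place: isopentyl in place of 3-methylphenyl on a saturated chain carbon bound to a carbonyl carbon and an oxygen on a saturated carbon. For the measured compounds named here, no measured pair shows a step of this kind, so its size has to be judged without a direct comparison. The step from compound 2 to compound 3 is expected to be an at least 2.5-fold higher number from compound 2 to compound 3 (0.39 log units; beyond the scatter), a rise beyond the usual scatter, although a result that again stops at the limit remains possible. For compound 3 the estimated value is 30 mL.min-1.g-1, with a range from 10 mL.min-1.g-1 to 90 mL.min-1.g-1.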

Compound 3, intrinsic clearance in microsomes: 47 mL.min-1.g-1
Compound 3: middle estimate off by 1.6-fold (0.19 log units), on the low side; low and high end bracket the measured number.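

In this assay, for the compounds shown here, putting isopentyl in place of 3-methylphenyl gives an at least 3.9-fold higher number from compound 2 to compound 3 (0.59 log units; beyond the scatter) and is the first single change that can be read here. With the rest of the molecule unchanged, this shows that the group on this saturated chain carbon has a clear bearing on how fast the compound is removed. The step gives only a lower bound on the change, because one end of it rests on a limit of the assay and not a number: the limit of < 12 mL.min-1.g-1 in this assay, at which 1 of the 3 values shown sits.

The exchange removes the aromatic ring and also changes the carbon count, so this one pair cannot show which of the two matters. Going by these compounds, a cyclohexyl group at the same place would keep a ring without aromatic character, and how it behaves remains open.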